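Working notes on the amide aryl group, compounds 1 to 4

This account rests on a few compounds, and the source may have more. Where it says the series, first, only, none or still open, it means among the compounds named here.

Measured so far in an assay on HEK293 cells for displacement of a labelled ligand from metabotropic glutamate receptor 5 (Rattus norvegicus); a higher number here means a weaker inhibitor, a lower number a stronger inhibitor:
- compound 1 `O=C(Nc1cc(-c2ccccc2)nn1-c1ccccc1)c1ccccc1`: 4180 nM
- compound 2 `O=C(Nc1cc(-c2ccccc2)nn1-c1ccccc1)c1ccc(OC(F)(F)F)cc1`: 265 nM
- compound 3 `O=C(Nc1cc(-c2ccccc2)nn1-c1ccccc1)c1ccc([N+](=O)[O-])cc1`: 250 nM

Compound 3 carries the lowest number of the three, with compound 2 within the scatter of it and compound 1 far higher. Compound 4 `Cc1ccc(C(=O)Nc2cc(-c3ccccc3)nn2-c2ccccc2)cn1` differs from compound 3 by 6-methylpyridin-3-yl in place of 4-nitrophenyl on a carbonyl carbon. Among the compounds with values here, no measured step covers an aryl-to-heteroaryl exchange at this position. What bears on it is a 17-fold lower number from compound 1 to compound 3 (1.22 log units; beyond the scatter), showing how much the nitro contributes, and a 1.1-fold lower number from compound 2 to compound 3 (0.03 log units; within the scatter), showing two such substituents interchangeable. The entering ring lacks both; the expectation in this assay is therefore a step toward compound 1, though not necessarily all the way, estimated as a 6.0-fold higher number from compound 3 to compound 4 (0.78 log units; beyond the scatter). Compound 4 is expected at 1500 nM, range 400 nM to 6000 nM.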

Compound 4, inhibition constant: 3480 nM
For compound 4 the middle estimate is 2.3-fold (0.37 log units) below the measured one, and the stated range covers the measured number.
By their numbers in this assay, from the lowest: compounds 3 and 2 (each within the scatter of the next); then compounds 4 and 1 (each within the scatter of the next).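

In this assay, 6-methylpyridin-3-yl in place of 4-nitrophenyl on a carbonyl carbon gives a 14-fold higher number from compound 3 to compound 4 (1.14 log units; beyond the scatter), while in place of phenyl it gives a 1.2-fold lower number from compound 1 to compound 4 (0.08 log units; within the scatter). This position therefore accepts the heteroaryl ring, but with no gain over plain phenyl, so the ring exchange does not stand in for the nitro or trifluoromethoxy substituent. Nothing measured here accounts for this result.

Open, as far as these compounds go, is whether the ring nitrogen or the methyl governs this outcome; a pyridine ring without the methyl, or a phenyl ring bearing it, would separate the two. Also open, from the compounds shown here alone, is whether an amine or a carboxylic acid on the phenyl ring would match the nitro.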